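This account rests on a few compounds, and the source may have more. Where it says the series, first, only, none or still open, it means among the compounds named here.

Measured compounds: compound 1 `O=C(N/N=C/c1cc(I)c(O)c(I)c1)c1ccccc1`, compound 2 `COc1ccc(C(=O)N/N=C/c2cc(I)c(O)c(I)c2)cc1` and compound 3 `O=C(N/N=C/c1cc(I)c(O)c(I)c1)c1ccc(Cl)cc1`. In a functional assay on HepG2 cells (Homo sapiens) for cytotoxicity, with a stated time of 24 h (a higher number here means a weaker inhibitor, a lower number a stronger inhibitor), compound 1 gives 191000 nM. For compound 2 the read-out is only the limit > 100000 nM. For compound 3 likewise only the limit > 100000 nM is recorded, so compound 3 stands at the edge of what this assay reports, as one of the two values sitting at the limit of > 100000 nM in this assay, at which 2 of the 3 values shown sit. Compound 4 `O=C(N/N=C/c1cc(I)c(O)c(I)c1)c1ccc(C(F)(F)F)cc1` is not yet measured; it differs from compound 3 by trifluoromethyl in place of chloro on an aromatic carbon. Going by the values given here, the steps that bear on this change are a step that the limit leaves unreadable from compound 1 to compound 2, a step that the limit leaves unreadable from compound 1 to compound 3 and a step that the two limits leave unreadable from compound 2 to compound 3, none of which has a readable size. The step from compound 3 to compound 4 is therefore expected to be a step that the limit leaves unreadable from compound 3 to compound 4, most likely another limit. Compound 4 is estimated at 150000 nM, within 70000 nM to 350000 nM.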

Compound 4, half-maximal inhibitory concentration: 57400 nM
Compound 4: middle estimate off by 2.6-fold (0.42 log units), on the high side, and the stated range ends above it.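

In this assay, trifluoromethyl on this aromatic carbon gives a readable number, where chloro and methoxy gave only limits: the limit of > 100000 nM in this assay, at which 2 of the 4 values shown sit. Against chloro the result is an at least 1.7-fold lower number from compound 3 to compound 4 (0.24 log units; that floor lies within the scatter), and against methoxy it is an at least 1.7-fold lower number from compound 2 to compound 4 (0.24 log units; that floor lies within the scatter), so both of these floors stay within the scatter. Against hydrogen the change is a 3.3-fold lower number from compound 1 to compound 4 (0.52 log units; beyond the scatter), the only step here that is readable in full and beyond the scatter.

The compounds shown leave open how far compound 2 and compound 3 truly lie from compound 4. They also leave open what an amine, a carboxylic acid or a longer chain would give at this position.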